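The source may hold more compounds than are shown below. What is called first, only, known or untested is meant among the compounds shown, and "the series" means these compounds.

Compound 2 `NC1=NC2(CCOCC2)N(OCCCOc2ccc(Br)cc2)C(N)=N1` stands as the lower of the two numbers recorded so far in an assay on isolated protein for inhibition of Dihydrofolate reductase (Homo sapiens), read by spectrophotometry, using NADPH, with stated times of 5 s and 6 min (a lower number here means a stronger inhibitor, a higher number a weaker inhibitor), where compound 2 gives 32.5 nM. Among the compounds with values here, its only neighbour is compound 1 `NC1=NC2(CCOCC2)N(OCCCOc2ccccc2)C(N)=N1`, which in this assay gives 86.1 nM. Within the data shown here, the single measured step, a 2.6-fold lower number from compound 1 to compound 2 (0.42 log units; beyond the scatter), is the one that bears on what follows, since it changed the same aromatic carbon.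

Compound 3 `CC(C)(C)c1ccc(OCCCON2C(N)=NC(N)=NC23CCOCC3)cc1` is reached from compound 2 by the change (tert-butyl in place of bromo on an aromatic carbon). Among the measured compounds shown here, no measured pair exchanges bromo for tert-butyl, so the expectation can rest only on the modest gain seen in a 2.6-fold lower number from compound 1 to compound 2 (0.42 log units; beyond the scatter) when that position was first occupied. Given that a group at this position already produced a step beyond the scatter, compound 3 is expected to keep a number close to compound 2 in this assay, with the estimated step of a 1.3-fold lower number from compound 2 to compound 3 (0.10 log units; within the scatter) lying within the scatter. For compound 3 the estimated value in this assay is 26 nM, with a range from 9 nM to 80 nM.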

Compound 3, half-maximal inhibitory concentration: 3.72 nM
Compound 3: middle estimate off by 7.0-fold (0.84 log units), on the high side, outside the stated range (below it).
By their numbers in this assay, from the lowest: compound 3; then compound 2; then compound 1.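

In this assay the result shows that the identity of the group on this aromatic carbon matters, and not merely whether the carbon is occupied: exchanging bromo for tert-butyl gives a further gain (an 8.7-fold lower number from compound 2 to compound 3 (0.94 log units; beyond the scatter)), larger than the one first seen on occupying the position. Measured from the hydrogen of compound 1, tert-butyl gives a large step (a 23-fold lower number from compound 1 to compound 3 (1.36 log units; beyond the scatter)), where bromo gave only a modest one (a 2.6-fold lower number from compound 1 to compound 2 (0.42 log units; beyond the scatter)), so the first substitution had not shown how much this position could yield. No measurement at hand accounts for the difference between the two groups.

The three compounds carry only hydrogen, bromo and tert-butyl at this one position, so they leave open whether the number keeps falling with other carbon groups, such as isopropyl, cyclohexyl or phenyl, or what an amine or a carboxylic acid would do there. They also leave open whether the gain from tert-butyl would hold with a longer chain joining the aromatic ring to the shared core.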